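The source may report more compounds than this note shows. Statements on the series, on what has been measured and on what is new or still open speak of the compounds shown alone.

Measured compounds:
compound 1 `O=c1[nH]nc(NCc2ccccc2)cc1-c1ccccc1` — > 10000 nM
compound 2 `O=c1cc(-c2ccccc2)c(NCc2ccccc2)n[nH]1` — > 10000 nM
compound 3 `CCCNc1cc(-c2ccccc2)c(=O)[nH]n1` — > 10000 nM

In an assay for inhibition of casein kinase I isoform alpha (Sus scrofa), read by scintillation counting and 33P incorporation, with a stated time of 30 min, in the presence of a further agent that is not named here (a higher number here means a weaker inhibitor, a lower number a stronger inhibitor), compound 1 gives > 10000 nM, which is a limit of the assay and not a number. In this assay compound 2 gives > 10000 nM, again a limit. Compound 3 likewise gives > 10000 nM in this assay, a limit. Compound 1 and compound 2 share the same atoms joined differently; the difference between the two cores is not broken down here. From compound 1 to compound 3 the change is ethyl in place of phenyl on a saturated chain carbon bound to a nitrogen on an aromatic ring, and the step it made, a step that the two limits leave unreadable from compound 1 to compound 3, cannot be read from two limits. The same change, (ethyl in place of phenyl on a saturated chain carbon bound to a nitrogen on an aromatic ring), leads from compound 2 to the unmeasured compound 4 `CCCNc1n[nH]c(=O)cc1-c1ccccc1`. With both ends of the earlier pair at the limit, (the limit of > 10000 nM in this assay, at which 3 of the 3 values shown sit), no readable step is available. In this assay compound 4 is expected to sit at about 20000 nM, between 5000 nM and 100000 nM, an expected step that the limit leaves unreadable from compound 2 to compound 4, most likely reported as a limit again.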

Compound 4, half-maximal inhibitory concentration: > 10000 nM
Compound 4 ended at the assay's limit; the forecaster's own chance of this, stated with the estimate: 85%; the middle value does not contradict the limit.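

No step can be read from compound 2 to compound 4, as both values in this assay are limits: the limit of > 10000 nM in this assay, at which 4 of the 4 values shown sit.

The compounds shown leave open whether any compound of this series gives a readable value in this assay.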